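The source may hold more compounds than are shown below. What is called first, only, known or untested is meant among the compounds shown, and "the series" means these compounds.

In a functional assay on MCF7 cells (Homo sapiens) for antiproliferative activity, read by MTT assay, with a stated time of 48 h; on this read-out higher numbers stand for weaker inhibition and lower numbers for stronger inhibition:
compound 1 `O=C(Nc1cccc(/C=C/C(=O)c2nc3ccccc3[nH]2)c1)c1cccc(Cl)c1`: 7840 nM
compound 2 `O=C(Nc1cccc(/C=C/C(=O)c2nc3ccccc3[nH]2)c1)c1ccc(Cl)cc1`: 8410 nM
compound 3 `COc1cccc(C(=O)Nc2cccc(/C=C/C(=O)c3nc4ccccc4[nH]3)c2)c1`: 17800 nM

Compound 3 gives the highest of the three numbers, with a 2.3-fold higher number from compound 1 to compound 3 (0.36 log units; beyond the scatter) and a 2.1-fold higher number from compound 2 to compound 3 (0.33 log units; beyond the scatter); the two chloro compounds sit within the scatter of each other, a 1.1-fold higher number from compound 1 to compound 2 (0.03 log units; within the scatter). Compound 4 `O=C(/C=C/c1cccc(NS(=O)(=O)c2ccccc2Cl)c1)c1nc2ccccc2[nH]1` is derived from compound 3 by (2-chlorophenyl)sulfonyl in place of (3-methoxyphenyl)carbonyl on a nitrogen on an aromatic ring. Within the data shown here, no measured step exchanges a carbonyl for a sulfonyl, so nothing bears directly on this change; the only related steps are the two above, in which each chloro compound gives a lower number than the methoxy compound. Chlorine re-enters in compound 4, and on the showing of a 2.3-fold higher number from compound 1 to compound 3 (0.36 log units; beyond the scatter) a modest lowering in this assay is expected, with wide uncertainty from the sulfonyl. Compound 4 is estimated at 9000 nM (range 3000 nM to 27000 nM), the expected step being a 2.0-fold lower number from compound 3 to compound 4 (0.30 log units; within the scatter).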

Compound 4, half-maximal inhibitory concentration: 4280 nM
Compound 4: middle estimate off by 2.1-fold (0.32 log units), on the high side; the range from low to high includes it.
By their numbers in this assay, from the lowest: compounds 4, 1 and 2 (each within the scatter of the next); then compound 3.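

In this assay, the step at this nitrogen on an aromatic ring from (3-methoxyphenyl)carbonyl to (2-chlorophenyl)sulfonyl gives the largest change so far (a 4.2-fold lower number from compound 3 to compound 4 (0.62 log units; beyond the scatter)). Against the chloro amides, the sulfonyl shows no separable change (a 2.0-fold lower number from compound 2 to compound 4 (0.29 log units; within the scatter); a 1.8-fold lower number from compound 1 to compound 4 (0.26 log units; within the scatter)), so compounds 1, 2 and 4 form one group, with compound 3 apart. No measurement on hand accounts for these results.

The sulfonyl and the chlorine change together from compound 3 to compound 4, leaving their separate contributions open. So too is the outcome with (3-methoxyphenyl)sulfonyl, or with a carboxylic acid or an amine on the aromatic ring of the sulfonyl.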